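A few compounds are considered here, and "the series" means these few. Any claim that something is new, unique, unknown or untested is made for them only; others in the source may bear on it.

Working notes on the series. Of the compounds shown here, three have been measured in an assay on cells for inhibition of S-adenosylmethionine decarboxylase proenzyme (Homo sapiens), read by mass spectrometry, at pH 7.2, tested at 180 uM; on this read-out higher numbers stand for more inhibition at the one concentration tested (going by the name of the read-out) and lower numbers for less inhibition. Compound 1 `CCc1cc(Nc2cc(Cl)cc(Cl)c2)nc(N)n1` gives 36% in this assay. Compound 2 `Cc1cc(Nc2cc(Cl)cc(Br)c2)nc(N)n1` gives 33% in this assay. Compound 3 `CCOc1cc(Br)cc(Nc2cc(C)nc(N)n2)c1` gives 36% in this assay. Going by the values given here, the one single-point step among them is ethoxy in place of chloro on an aromatic carbon, a number 3 percentage points higher from compound 2 to compound 3 (within the scatter), a difference that does not stand out from repeat-to-repeat variation. On the numbers shown compound 3 sits level with compound 1 at the digits given and within the scatter of compound 2, so the three measured values are indistinguishable.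

The next compound, compound 4 `C=CCOc1cc(Br)cc(Nc2cc(C)nc(N)n2)c1`, differs from compound 3 in one place: vinyl in place of methyl on a saturated chain carbon bound to an oxygen on an aromatic ring. Among the compounds with values here, no measured pair varies at this place; the only step on record, a number 3 percentage points higher from compound 2 to compound 3 (within the scatter), concerns the substituent on the aromatic carbon and was itself within the scatter. There is therefore no measured basis for a step beyond the scatter in either direction, and the working expectation for compound 4 is a value in this assay close to that of compound 3, with a step of no change at the digits printed from compound 3 to compound 4 (within the scatter) expected. Compound 4 is estimated at 36% in this assay, with an expected range from 22% to 50%.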

Compound 4, a percentage reported as inhibition, at one concentration (the size of the read-out at that concentration, not a potency): 28%
The estimate for compound 4 lay 8 percentage points above the measured number, within the range that was stated.
By their numbers in this assay, from the lowest: compounds 4, 2, 1 and 3 (each within the scatter of the next).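

In this assay, the chain on the oxygen now has a step of its own: ethoxy to allyloxy, vinyl in place of methyl on a saturated chain carbon bound to an oxygen on an aromatic ring, gives a number 8 percentage points lower from compound 3 to compound 4 (within the scatter) and so adds no difference that stands out from repeat-to-repeat variation. Exchanging chloro for allyloxy on an aromatic carbon gives a number 5 percentage points lower from compound 2 to compound 4 (within the scatter), and this second oxygen-linked group therefore joins ethoxy, with a number 3 percentage points higher from compound 2 to compound 3 (within the scatter) on record, in showing no step beyond the scatter at that carbon. No evidence is available on what lies behind these numbers.

The compounds shown leave open whether a longer chain such as butoxy, or an amine or a carboxylic acid carried at the end of the chain on the oxygen, would give a step beyond the scatter in this assay. Also open, from the compounds shown here alone, is whether a small group such as hydroxyl or a nitrile on the same aromatic carbon would separate from the values seen so far, since the four compounds in hand form a run in which each lies within the scatter of the next.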